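Ring substituent steps on the shared core toward compound 4

The compounds below may be only part of what the source reports. "The series", "measured", "known", "first", "only" and "open" are said of these compounds alone.

Measured in an assay on CHO cells for displacement of a labelled ligand from adenosine receptor A1 (Homo sapiens), read by scintillation counting, with a stated time of 120 min, tested at 1 uM; a lower number here means less inhibition, a higher number more inhibition at the concentration tested (going by the name of the read-out):
compound 1 `Cc1nc2sc(-c3ccccc3)nc2c(=O)[nH]1` gives 11%
compound 2 `Cc1nc2sc(-c3ccc(C(F)(F)F)cc3)nc2c(=O)[nH]1` gives 1%
compound 3 `Cc1nc2sc(-c3ccc(C(=O)O)cc3)nc2c(=O)[nH]1` gives 1%

Compound 1 has the highest of the three numbers, yet neither neighbour is separated from it beyond the usual scatter: the nearest, compound 2, sits a number 10 percentage points lower from compound 1 to compound 2 (within the scatter), and the furthest, compound 3, sits a number 10 percentage points lower from compound 1 to compound 3 (within the scatter). Between the two substituted analogues there is no change at the digits printed from compound 2 to compound 3 (within the scatter). All three numbers therefore describe a flat, low-inhibition series in this assay.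

Compound 4 `Cc1cccc(-c2nc3c(=O)[nH]c(C)nc3s2)c1` differs from compound 1 by methyl in place of hydrogen on an aromatic carbon.

For the measured compounds named here, the steps that bear on this change are the two in which a hydrogen on the same ring of compound 1 was replaced: by trifluoromethyl, a number 10 percentage points lower from compound 1 to compound 2 (within the scatter), and by carboxy, a number 10 percentage points lower from compound 1 to compound 3 (within the scatter). Both stayed within the scatter, and neither substituent resembles methyl in what it brings, so they inform only on the likely size of the step, not on a direction. The expected step in this assay is accordingly a number 3 percentage points lower from compound 1 to compound 4 (within the scatter), that is, none beyond the scatter. Compound 4 is estimated at 8%, within a range of 0% to 24%.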

Compound 4, a percentage reported as inhibition, at one concentration (the size of the read-out at that concentration, not a potency): 1%
Compound 4: the middle estimate sits 7 percentage points above what was measured; low and high end bracket the measured number.
By their numbers in this assay, from the lowest: compounds 2, 3, 4 and 1 (each within the scatter of the next).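

Methyl on an aromatic carbon, meta to a large group, adds one carbon and no hydrogen-bond donor or acceptor, and in this assay this change gives a number 10 percentage points lower from compound 1 to compound 4 (within the scatter). Read alongside the trifluoromethyl and carboxy replacements on the same ring, this makes a third substitution of compound 1 that produces no step beyond the scatter, so a group as small as methyl at this place also leaves the read-out unresolved from that of the parent. No measurement offered here explains this result or gives any property of the methyl group that could be tied to it.

Still open, going by these compounds, is whether an amine, a hydroxyl group or a longer chain such as ethyl or propyl at this same place would give a step beyond the scatter in either direction. Also open is whether replacing the phenyl ring altogether, or exchanging the methyl on the shared core for a longer chain, would take the series out of this flat, low-inhibition band, since the compounds shown vary only the substituent on the phenyl ring.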